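Microsomal half-life: ethyl homologue of compound 3

This account rests on a few compounds, and the source may have more. Where it says the series, first, only, none or still open, it means among the compounds named here.

Measured so far:
compound 1, `CCCCc1ccc(NC(=O)N2CCCN(C(=O)CCC3CCCC3)CC2)cc1`, gives 0.0833 h in an in vitro ADME assay on microsomes from liver (Homo sapiens) for metabolic stability, read by LC-MS; on this read-out higher numbers stand for a longer-lived compound and lower numbers for a shorter-lived compound
compound 2, `O=C(CCC1CCCC1)N1CCCN(C(=O)Nc2ccccc2)CC1`, gives 0.05 h in this assay
compound 3, `Cc1ccc(NC(=O)N2CCCN(C(=O)CCC3CCCC3)CC2)cc1`, gives 0.0667 h in this assay

Compound 3 sits between its two neighbours on the numbers shown, and both gaps are small: a 1.2-fold lower number from compound 1 to compound 3 (0.10 log units; within the scatter) and a 1.3-fold higher number from compound 2 to compound 3 (0.13 log units; within the scatter). All three measured numbers lie within the scatter of one another, so no ordering among them is established.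

Compound 4 is `CCc1ccc(NC(=O)N2CCCN(C(=O)CCC3CCCC3)CC2)cc1`. The change from compound 3 is methyl in place of hydrogen on a saturated chain carbon bound to an aromatic carbon. Within the data shown here, two measured steps bear on this position. Removing the whole propyl piece from the chain carbon bound to the aromatic carbon gave a 1.2-fold lower number from compound 1 to compound 3 (0.10 log units; within the scatter), and adding the methyl to the bare aromatic carbon gave a 1.3-fold higher number from compound 2 to compound 3 (0.13 log units; within the scatter); neither left the scatter. Lengthening the chain by one further carbon is therefore not expected to move this assay beyond the scatter in either direction.

Compound 4 is estimated at 0.072 h, with a range of 0.04 h to 0.13 h. The expected step is a 1.1-fold higher number from compound 3 to compound 4 (0.03 log units; within the scatter).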

Compound 4, half-life: 0.0833 h
Beside the measured number, compound 4's estimate is 1.2-fold (0.06 log units) below it, within the range that was stated.
By their numbers in this assay, from the lowest: compounds 2, 3, 1 and 4 (each within the scatter of the next).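

In this assay the methyl to ethyl change gives a 1.2-fold higher number from compound 3 to compound 4 (0.10 log units; within the scatter) and the whole ethyl group in place of hydrogen on the aromatic carbon gives a 1.7-fold higher number from compound 2 to compound 4 (0.22 log units; within the scatter) so this extension, until now only bracketed by neighbouring steps, has a direct reading that stays inside the scatter. The ethyl and butyl compounds cannot be told apart, with no change at the digits printed from compound 1 to compound 4 (within the scatter) and across hydrogen, methyl, ethyl and butyl at this place, all four compounds lie within the scatter of one another, so no trend with chain length is established. Nothing available explains these small steps or gives a reason for the flat response.

From the compounds shown here alone, whether a group of a different kind at this place, such as an amine, a carboxylic acid or a methoxy group, or a chain longer than butyl, would take this assay beyond the scatter remains open. Also open, going by these compounds, is whether any change elsewhere on the shared core would move this read-out, since all the differences shown sit on this one substituent.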